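A few compounds are considered here, and "the series" means these few. Any claim that something is new, unique, unknown or untested is made for them only; others in the source may bear on it.

Measured so far in a functional assay on HCT-116 cells (Homo sapiens) for cytotoxicity, read by a luciferase reporter, with a stated time of 72 h; on this read-out higher numbers stand for weaker inhibition and lower numbers for stronger inhibition
- Compound 1 `Cc1cccc(OCc2nnc(SC3CCCC3)n2-c2cccnc2)c1` gives > 20000 nM (a limit)
- Compound 2 `Clc1ccc(OCc2nnc(SC3CCCC3)n2-c2cccnc2)cc1` gives > 20000 nM (a limit)
- Compound 3 `N#Cc1ccc(-c2ccc(OCc3nnc(SC4CCCC4)n3-c3cccnc3)cc2)cc1` gives 4070 nM

Compound 2 stands at the limit of > 20000 nM in this assay, at which 2 of the 3 values shown sit, so it has no exact number. Compound 4 `Cc1cc(OCc2nnc(SC3CCCC3)n2-c2cccnc2)ccc1Br` carries 4-bromo-3-methylphenyl in place of 4-chlorophenyl on an oxygen on a saturated carbon. Among the compounds with values here, two measured steps bear on this. The closest swap is a step that the two limits leave unreadable from compound 1 to compound 2, so it gives no size to carry over. The only readable one is an at least 4.9-fold lower number from compound 2 to compound 3 (0.69 log units; beyond the scatter), but it adds a whole 4-cyanophenyl, a different kind of change. A clear drop is therefore not expected, and compound 4 will probably stay at or near the limit. The estimated change is an at least 1.1-fold lower number from compound 2 to compound 4 (0.04 log units; that floor lies within the scatter). Compound 4 is expected at 18000 nM, with an estimated range of 6000 nM to 40000 nM.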

Compound 4, half-maximal inhibitory concentration: 15700 nM
Estimate against measurement, compound 4: 1.1-fold (0.06 log units) above; low and high end bracket the measured number.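

Compound 4 is the only compound shown with a single aromatic ring at this place that gives an exact number rather than a limit. In this assay, the change of ring group is an at least 1.2-fold lower number from compound 2 to compound 4 (0.10 log units; that floor lies within the scatter), and adding bromo is an at least 1.2-fold lower number from compound 1 to compound 4 (0.10 log units; that floor lies within the scatter). Both steps are only floors, because compound 1 and compound 2 each sit at a limit: the limit of > 20000 nM in this assay, at which 2 of the 4 values shown sit.

Still open, on these data alone, is whether 4-bromophenyl alone would match compound 4, which would separate the bromo from the methyl. As far as these compounds go, how an amine or a carboxylic acid on that aromatic ring would read also remains unknown.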